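The source may report more compounds than this note shows. Statements on the series, on what has been measured and on what is new or still open speak of the compounds shown alone.

Three compounds share one core: compound 1 (`CC1(C)C(=O)N(c2ccc(SC(F)(F)F)cc2)C(=O)N1Cc1ccnc(N2CCCCC2)c1`), compound 2 (`CC1(C)C(=O)N(c2ccc(SC(F)(F)F)cc2)C(=O)N1Cc1ccnc(N2CCNCC2)c1`) and compound 3 (`CC1(C)C(=O)N(c2ccc(SC(F)(F)F)cc2)C(=O)N1Cc1ccnc(NC2CCCCC2)c1`). In a physicochemical assay for solubility, read by nephelometry (a higher number here means a more soluble compound, a lower number a less soluble compound), compound 1 gives < 0.024 ug/mL as a limit of the assay, not a number. Compound 2 gives < 0.024 ug/mL as a limit too. Compound 3 gives < 0.025 ug/mL as its limit, so it has no exact place among the three, whose values are all limits.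

Compound 4 (`COc1ccc(CNc2cc(CN3C(=O)N(c4ccc(SC(F)(F)F)cc4)C(=O)C3(C)C)ccn2)cc1`) is still unmeasured. It differs from compound 3 in one place (4-methoxybenzyl in place of cyclohexyl on a nitrogen on an aromatic ring): 4-methoxybenzyl in place of cyclohexyl on a nitrogen on an aromatic ring.

The measured steps that bear on this are changes of the group on the same aromatic carbon: a step that the two limits leave unreadable from compound 1 to compound 3 and a step that the two limits leave unreadable from compound 2 to compound 3 and also a step that the two limits leave unreadable from compound 1 to compound 2 in the same way. None offers a size to carry over, so no step beyond the scatter is expected in this assay and no direction can be given. The expected outcome is a number no lower from compound 3 to compound 4 (the limit leaves the size open) as an estimate resting on compound 3 and its limit (< 0.025 ug/mL). The estimate for compound 4 is 0.025 ug/mL with an expected range from 0.01 ug/mL to 0.08 ug/mL as its span.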

Compound 4, solubility: < 0.027 ug/mL
Compound 4: only a limit was reported (the forecaster's own chance of this, stated with the estimate: 85%); the middle value does not contradict the limit.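

Within the data shown here, compound 4 gives only a limit of the assay, so no step from compound 1, compound 2 or compound 3 to compound 4 can be read in this assay: the limit of < 0.027 ug/mL in this assay, at which 1 of the 4 values shown sits. The compounds shown leave open the actual solubility of all four, and whether 4-methoxybenzyl in place of cyclohexyl changes it at all.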